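Cytotoxicity series: all three values at the assay limit

The source may report more compounds than this note shows. Statements on the series, on what has been measured and on what is new or still open speak of the compounds shown alone.

Of the compounds shown here, three of the shared core have been measured in a functional assay on HEK293 cells (Homo sapiens) for cytotoxicity; a higher number here means that more compound is tolerated, a lower number that less compound is tolerated. Compound 1 `COc1ccc([C@H]2CC(=O)N(c3cccc(O)c3)C2)cc1OC1CCCC1` returns only a limit, > 10000 nM. Compound 2 `COc1ccc([C@H]2CC(=O)N(c3ccccc3C#N)C2)cc1OC1CCCC1` likewise returns only a limit, > 10000 nM. Compound 3 `COc1ccc([C@H]2CC(=O)N(c3cccc(S(C)(=O)=O)c3)C2)cc1OC1CCCC1` also returns only a limit, > 10000 nM. On the numbers shown, compound 2 therefore stands at no readable point: its value is a limit, and the two further values shown are limits as well, as the limit of > 10000 nM in this assay, at which 3 of the 3 values shown sit, records. The steps among the three cannot be sized: a step that the two limits leave unreadable from compound 1 to compound 2, a step that the two limits leave unreadable from compound 1 to compound 3 and a step that the two limits leave unreadable from compound 2 to compound 3 are each unreadable and show no direction.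

Compound 4 `COc1ccc([C@H]2CC(=O)N(c3ccc(S(C)(=O)=O)cc3)C2)cc1OC1CCCC1` differs from compound 2 in one place: 4-(methylsulfonyl)phenyl in place of 2-cyanophenyl on an amide-type nitrogen in a ring. The measured step that touches the same nitrogen with a methylsulfonyl-bearing ring, a step that the two limits leave unreadable from compound 2 to compound 3, is unreadable, and no step in this assay has shown a size at all. No step beyond the scatter is therefore expected in either direction, and compound 4 is expected to stay at the limit as well. The estimate for compound 4 is 15000 nM, within 8000 nM to 30000 nM. The step this estimate implies, a step that the limit leaves unreadable from compound 2 to compound 4, is expected to lie within the scatter.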

Compound 4, half-maximal cytotoxic concentration: > 10000 nM
Compound 4: only a limit was reported (the forecaster's own chance of this, stated with the estimate: 85%); the middle value does not contradict the limit.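

In this assay compound 4 returns only a limit, > 10000 nM. No new step can be read between compound 4 and compound 1, compound 2 or compound 3, as all four values are limits: the limit of > 10000 nM in this assay, at which 4 of the 4 values shown sit. Still open, as far as these compounds go, is whether any group on the amide-type nitrogen of the shared core gives a readable value in this assay.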